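Aryl ether to aryl thioether exchange on the shared core

The source may hold more compounds than are shown below. What is called first, only, known or untested is meant among the compounds shown, and "the series" means these compounds.

Within the data shown here, compound 2 `Nc1cc(N)c2nc(-c3ccccc3)c(Oc3ccc(F)cc3)nc2c1` gives 18200 nM in a functional assay on NCI/ADR-RES cells (Homo sapiens) for inhibition, read by sulforhodamine B assay, with a stated time of 48 h (on this read-out higher numbers stand for weaker inhibition of growth and lower numbers for stronger inhibition of growth), the second highest of the three numbers so far, within the scatter of compound 3 `COc1ccc(CNc2nc3cc(N)cc(N)c3nc2-c2ccccc2)cc1` at 22900 nM and of compound 1 `Nc1cc(N)c2nc(-c3ccccc3)c(Oc3ccc(Cl)c(Cl)c3)nc2c1` at 11700 nM. Among the measured compounds shown here, the only single-place step recorded is a 1.6-fold higher number from compound 1 to compound 2 (0.19 log units; within the scatter). Compound 4 `COc1ccc(Sc2nc3cc(N)cc(N)c3nc2-c2ccccc2)cc1` differs from compound 2 by (4-methoxyphenyl)sulfanyl in place of 4-fluorophenoxy on an aromatic carbon. For the measured compounds named here, no measured step exchanges oxygen for sulfur at this position, and compound 3, which also carries a 4-methoxyphenyl group, stands within the scatter of compound 2. The expectation is therefore a step no larger than the scatter, a 1.0-fold lower number from compound 2 to compound 4 (0.00 log units; within the scatter). Compound 4 is estimated at 18000 nM, with a range from 8000 nM to 40000 nM.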

Compound 4, concentration for 50% growth inhibition: < 100000 nM
Compound 4 was reported as a limit; the forecaster's own chance of this, stated with the estimate: 10%; the middle value lies beyond the limit too.
By their numbers in this assay, from the lowest: compounds 1, 2 and 3 (each within the scatter of the next).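

Compound 4 gives < 100000 nM in this assay, which is a limit and not a number. The steps to it from compound 1 and compound 2 cannot be read. As far as these compounds go, whether (4-methoxyphenyl)sulfanyl in place of 4-fluorophenoxy changes growth inhibition at all stays open.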